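Chloro position on the anilino ring: compound 3

The compounds below may be only part of what the source reports. "The series", "measured", "known", "first", "only" and "open" are said of these compounds alone.

Measured so far:
compound 1 `C#CCSc1nc(Nc2cccc(C(F)(F)F)c2)c(C#N)c(-c2ccccc2)n1` — 61100 nM
compound 2 `C#CCSc1nc(Nc2ccc(Cl)cc2)c(C#N)c(-c2ccccc2)n1` — 19800 nM

The two measured compounds share one core and differ only in the substituent on the anilino ring. In a functional assay on B16-F10 cells (Mus musculus) for inhibition, read by MTT assay, with a stated time of 72 h (on this read-out lower numbers stand for stronger inhibition and higher numbers for weaker inhibition), compound 1 gives 61100 nM. Compound 2 gives the lower number of the two, 19800 nM, and its gap to compound 1 lies beyond the scatter, so on these two values compound 2 stands as the stronger inhibitor.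

Compound 3 `C#CCSc1nc(Nc2cccc(Cl)c2)c(C#N)c(-c2ccccc2)n1` is not yet measured. Relative to compound 2 the change is 3-chlorophenyl in place of 4-chlorophenyl on a nitrogen on an aromatic ring: the same atoms, joined differently. Among the compounds with values here, no step between two measured compounds covers this change, so no direct precedent exists. Compound 1 also carries its group at the 3-position and sits at the weaker end, but its group is not chlorine, so it gives only a loose pointer. A modest loss, possibly within the scatter, is expected for compound 3, with a 1.5-fold higher number from compound 2 to compound 3 (0.18 log units; within the scatter) as the estimated step and 30000 nM (range 10000 nM to 90000 nM) as the estimated value.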

Compound 3, half-maximal inhibitory concentration: 10500 nM
The estimate for compound 3 lay 2.9-fold (0.46 log units) above the measured number; the range from low to high includes it.
By their numbers in this assay, from the lowest: compounds 3 and 2 (each within the scatter of the next); then compound 1.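

In this assay, moving the chlorine gives a 1.9-fold lower number from compound 2 to compound 3 (0.28 log units; within the scatter), so 3-chlorophenyl and 4-chlorophenyl are not separated on this read-out, and the placement of chlorine on the anilino ring is not shown to matter between these two groups. The exchange of groups on the aromatic carbon gives a 5.8-fold lower number from compound 1 to compound 3 (0.76 log units; beyond the scatter), which is beyond the scatter and shows that the weak end of this small set goes with trifluoromethyl rather than with the group's placement alone. No measurement is available that would account for either step.

As far as these compounds go, whether a methoxy group, an amine or a carboxylic acid on the anilino ring would move the number beyond the scatter remains open. So does the effect of an unsubstituted phenyl at this place, which would give the chloro compounds a reference point.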